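The compounds below may be only part of what the source reports. "The series", "measured", "known", "first", "only" and "open" are said of these compounds alone.

Measured compounds:
compound 1 `COc1cc(C2=NOC(c3c[nH]c4ccccc34)C2)cc(OC)c1OC` gives 15500 nM in a functional assay on PC-3 cells (Homo sapiens) for inhibition, read by MTT assay, with a stated time of 48 h; a lower number here means a stronger inhibitor, a higher number a weaker inhibitor
compound 2 `COc1ccc(C2=NOC(c3c[nH]c4ccccc34)C2)cc1OC` gives 70100 nM in this assay

Compound 1 stands at the lowest of the two numbers seen so far; its nearest neighbour is compound 2, and the step of a 4.5-fold higher number from compound 1 to compound 2 (0.66 log units; beyond the scatter) shows that taking away one methoxy from the three-methoxy ring weakens the inhibitor by a modest but real margin. Compound 3 `COc1ccc2[nH]cc(C3CC(c4cc(OC)c(OC)c(OC)c4)=NO3)c2c1` keeps all three of those methoxy groups and instead adds a fourth one elsewhere: methoxy in place of hydrogen on an aromatic carbon, on the fused two-ring part of the core. Among the compounds with values here, no measured step touches that ring, so the only guide is that a methoxy on the other ring mattered modestly in the step from compound 1 to compound 2. The change is expected to be small, with a slight lean toward a lower number, as a 1.4-fold lower number from compound 1 to compound 3 (0.15 log units; within the scatter). For compound 3 the estimate is 11000 nM, within 3500 nM to 35000 nM.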

Compound 3, half-maximal inhibitory concentration: 42600 nM
Compound 3: the middle estimate sits 3.9-fold (0.59 log units) below what was measured; the measured number lies above the stated range.
By their numbers in this assay, from the lowest: compound 1; then compounds 3 and 2 (each within the scatter of the next).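

Methoxy in place of hydrogen on the aromatic ring that is part of the fused system of two rings gives a 2.7-fold higher number from compound 1 to compound 3 (0.44 log units; beyond the scatter) in this assay, so a change on this ring can move the number beyond the scatter, here toward a weaker inhibitor. The earlier step, a 4.5-fold higher number from compound 1 to compound 2 (0.66 log units; beyond the scatter), showed that losing a methoxy from the other ring also raises the number, whereas here gaining one does so: an added methoxy does not lower the number at every place on these compounds. Nothing measured here explains why this position responds in this way.

From the compounds shown here alone, it remains open whether methoxy would give a similar step at other places on the same ring. Going by these compounds, it is equally open whether a fluorine, a hydroxyl or an amine at this position would also raise the number, or would lower it instead.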